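Ester Chain Branching and Cell Migration in a Small Series

The source may hold more compounds than are shown below. What is called first, only, known or untested is meant among the compounds shown, and "the series" means these compounds.

Compound 1, `CCCC(=O)OCc1ccc2oc(=O)c(C(=O)Oc3cccc(Br)c3)cc2c1`, gives 24.7% in a functional assay on HT-1080 cells (Homo sapiens), read by transwell migration, with a stated time of 24 h, tested at 10 uM; on this read-out lower numbers stand for a stronger effect and higher numbers for a weaker effect at the one concentration tested.
Compound 2, `CCCCC(=O)OCc1ccc2oc(=O)c(C(=O)Oc3cccc(Br)c3)cc2c1`, gives 32.3% in this assay.
Compound 3, `CC(C)C(=O)OCc1ccc2oc(=O)c(C(=O)Oc3cccc(Br)c3)cc2c1`, gives 21.1% in this assay.

These three compounds share one core and differ only in the acyl part of the ester. Compound 1 and compound 2 are related by methyl in place of hydrogen on a saturated chain carbon, three bonds along the chain from a carbonyl carbon, and that change gave a number 7.6 percentage points higher from compound 1 to compound 2 (within the scatter). Compound 3 is related to compound 1 by isopropyl in place of propyl on a carbonyl carbon, which gave a number 3.6 percentage points lower from compound 1 to compound 3 (within the scatter), while from compound 2 to compound 3 the step was a number 11.2 percentage points lower from compound 2 to compound 3 (beyond the scatter).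

Compound 4, `CC(C)(C)C(=O)OCc1ccc2oc(=O)c(C(=O)Oc3cccc(Br)c3)cc2c1`, has not yet been measured. It differs from compound 3 by methyl in place of hydrogen on a saturated chain carbon bound to a carbonyl carbon and two saturated chain carbons. Going by the values given here, this is the same kind of change as the one from compound 1 to compound 2, but not the same: there the methyl entered on a saturated chain carbon, three bonds along the chain from a carbonyl carbon, whereas here it enters on a saturated chain carbon bound to a carbonyl carbon and two saturated chain carbons, and the two starting cores themselves differ by isopropyl in place of propyl on a carbonyl carbon.

Among the compounds with values here, the only measured example of adding a methyl to the chain gave a number 7.6 percentage points higher from compound 1 to compound 2 (within the scatter), so compound 4 is expected to show a step of a number 4.9 percentage points higher from compound 3 to compound 4 (within the scatter). Given that single reference, compound 4 is estimated at 26% in this assay, expected to fall between 15% and 38%.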

Compound 4, a percentage reported as activity, at one concentration (the size of the read-out at that concentration, not a potency): 23.6%
Estimate against measurement, compound 4: 2.4 percentage points above, and the stated range covers the measured number.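

In this assay, the methyl that turns isopropyl into tert-butyl gave a number 2.5 percentage points higher from compound 3 to compound 4 (within the scatter), and this step does not differ from the earlier methyl addition on the chain: the same change on two cores in this assay, a number 7.6 percentage points higher (within the scatter) from compound 1 to compound 2 and a number 2.5 percentage points higher (within the scatter) from compound 3 to compound 4, 5.1 percentage points apart, within the scatter of two such steps
The remaining comparisons also stay within the scatter, with tert-butyl in place of butyl giving a number 8.7 percentage points lower from compound 2 to compound 4 (within the scatter) and tert-butyl in place of propyl giving a number 1.1 percentage points lower from compound 1 to compound 4 (within the scatter). This shows that, across these two pairs, adding a methyl to the chain behaved alike on both cores, but it does not show that the change has any real effect of its own, since each step lies within the scatter, nor does it show that the likeness extends beyond these two pairs, in which the methyl also enters at different places.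

The compounds shown leave open how this read-out would respond to a longer chain such as hexanoyl, or to an acyl part carrying an amine or a carboxylic acid. They also leave open whether the methyl step would hold on a core with another group in place of the bromine, since every compound here carries that same bromine.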